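Moving a bromine on an inactive series

The source may report more compounds than this note shows. Statements on the series, on what has been measured and on what is new or still open speak of the compounds shown alone.

Measured compounds:
compound 1, `CCCCNc1nc(/C=C/c2ccccc2)nc2ccsc12`: > 1000000 nM
compound 2, `CN(c1ccccc1)c1nc(/C=C/c2ccccc2)nc2ccsc12`: > 1000000 nM
compound 3, `Brc1ccc(Nc2nc(/C=C/c3ccccc3)nc3ccsc23)cc1`: > 1000000 nM

All three compounds share one core and were tested in a functional assay on L02 cells (Homo sapiens) for inhibition, read by Griess assay, with stated times of 1 h and 24 h; a higher number here means a weaker inhibitor, a lower number a stronger inhibitor. Compound 1 gives > 1000000 nM, which is a limit of the assay and not a number. Compound 2 gives > 1000000 nM, again a limit. Compound 3 gives > 1000000 nM, also a limit. Because of the limit of > 1000000 nM in this assay, at which 3 of the 3 values shown sit, the three compounds cannot be ranked against one another, and the steps a step that the two limits leave unreadable from compound 1 to compound 2, a step that the two limits leave unreadable from compound 1 to compound 3 and a step that the two limits leave unreadable from compound 2 to compound 3 are all unreadable.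

Compound 4, `Brc1cccc(Nc2nc(/C=C/c3ccccc3)nc3ccsc23)c1`, differs from compound 3 in one place: 3-bromophenyl in place of 4-bromophenyl on a nitrogen on an aromatic ring. For the measured compounds named here, no measured step changes the position of a bromine on that ring, and the three steps that exist give no readable size. The expected step that the limit leaves unreadable from compound 3 to compound 4 in this assay is therefore estimated as none beyond the scatter, with compound 3 at the limit. Compound 4 is expected to give 2000000 nM in this assay, estimated between 200000 nM and 20000000 nM, most probably reported only as a limit again.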

Compound 4, half-maximal inhibitory concentration: > 1000000 nM
Compound 4: only a limit was reported; the forecaster's own chance of this, stated with the estimate: 85%; the middle value is on the limit's open side.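

Compound 4, like compound 1, compound 2 and compound 3, is reported only as a limit and not a number, so none of the steps among them can be read: the limit of > 1000000 nM in this assay, at which 4 of the 4 values shown sit.

The compounds shown leave open whether moving the bromine, or changing the group on the nitrogen in any other way, makes any difference in this assay.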